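Working notes: from compound 2 to compound 4

A few compounds are considered here, and "the series" means these few. Any claim that something is new, unique, unknown or untested is made for them only; others in the source may bear on it.

- compound 1 `CSc1ccc(NC(=O)Nc2cc(C)nc3ccccc23)cc1` gives 24000 nM as a measured number
- compound 2 `Cc1ccc(NC(=O)Nc2cc(C)nc3ccccc23)cc1` gives > 25000 nM as a limit
- compound 3 `Cc1cc(NC(=O)Nc2cccc(F)c2)c2ccccc2n1` gives > 25000 nM as a limit

In an ADME assay on HEK293 cells (Homo sapiens) for cytotoxicity, with a stated time of 72 h (on this read-out lower numbers stand for an effect already at smaller amounts and higher numbers for an effect only at larger amounts of compound), compound 2 gives > 25000 nM as a limit and not as a number. Compound 2 sits at the limit of > 25000 nM in this assay, at which 2 of the 3 values shown sit, and has no exact position. The change to compound 4 (`Cc1cc(NC(=O)Nc2ccc(C(F)(F)F)cc2)c2ccccc2n1`) is trifluoromethyl in place of methyl on an aromatic carbon. The closest measured change is an at least 1.0-fold higher number from compound 1 to compound 2 (0.01 log units; that floor lies within the scatter) for methyl in place of methylsulfanyl on an aromatic carbon. The other, a step that the two limits leave unreadable from compound 2 to compound 3 for 3-fluorophenyl in place of 4-methylphenyl on an amide-type nitrogen, gives no size. Neither supports a large move, so only a small shift to lower numbers, within the scatter, is expected. The estimated step is an at least 1.2-fold lower number from compound 2 to compound 4 (0.09 log units; that floor lies within the scatter) in this assay and may end at a limit again. The estimate for compound 4 is 20000 nM with an expected range from 8000 nM to 30000 nM in this read-out.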

Compound 4, half-maximal effective concentration: 25000 nM
Compound 4: middle estimate off by 1.3-fold (0.10 log units), on the low side; the range from low to high includes it.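

In this assay, with trifluoromethyl on the aromatic carbon para to a large group, compound 4 gives 25000 nM as a measured number, and the change from methylsulfanyl gives a 1.0-fold higher number from compound 1 to compound 4 (0.02 log units; within the scatter). Two different groups at this place thus give values within the scatter of each other. The change from methyl gives a number no higher from compound 2 to compound 4 (the limit leaves the size open). Compound 2 is held only by a limit: the limit of > 25000 nM in this assay, at which 2 of the 4 values shown sit.

From the compounds shown here alone, whether any group at this place moves the value beyond the scatter remains open. An amine or a carboxylic acid on this aromatic carbon would test that.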